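The source may hold more compounds than are shown below. What is called first, only, known or untested is meant among the compounds shown, and "the series" means these compounds.

Compound 1, with the structure `Cc1cccc(/C(N)=N/NC(=S)N2CCCCC2)n1`, is the starting point of this small set. In a functional assay on MCF7 cells (Homo sapiens) for cytotoxicity, read by MTT assay, with a stated time of 72 h, tested at 3 uM (a higher number here means more inhibition of growth at the concentration tested, a lower number less inhibition of growth), compound 1 gives 27.1%. Compound 2, with the structure `Cc1cccc(/C(N)=N/NC(=S)N2CCCC2)n1`, differs from it in one place: pyrrolidin-1-yl in place of piperidin-1-yl on a thiocarbonyl carbon. In this assay compound 2 gives 26.6%, so the step of a number 0.5 percentage points lower from compound 1 to compound 2 (within the scatter), which is a change too small to count as a real difference in this kind of measurement.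

Compound 3, with the structure `Cc1ccnc(/C(N)=N/NC(=S)N2CCCCC2)c1`, is built from the same atoms as compound 1 but joined differently; the difference between the two cores is not broken down here. In this assay compound 3 gives 29.4%. Its value, the value of compound 1 and the value of compound 2 all lie within the usual scatter of one another, so none of the three can be called more or less active than the others.

Compound 4, with the structure `Cc1ccnc(/C(N)=N/NC(=S)N2CCCC2)c1`, has not yet been measured. It stands to compound 3 exactly as compound 2 stands to compound 1: pyrrolidin-1-yl in place of piperidin-1-yl on a thiocarbonyl carbon, at a place whose surroundings are the same in both pairs, so this is the same change. Because the step of a number 0.5 percentage points lower from compound 1 to compound 2 (within the scatter) was within the scatter, the step of a number 0.4 percentage points lower from compound 3 to compound 4 (within the scatter) is expected to be of similar size, that is, no real change. Compound 4 is therefore estimated at 29%, with a range from 19% to 39% in this assay.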

Compound 4, percent growth inhibition at one concentration: 57.7%
Beside the measured number, compound 4's estimate is 28.7 percentage points below it, and the stated range ends below it.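

In this assay, putting pyrrolidin-1-yl in place of piperidin-1-yl on the thiocarbonyl carbon gives a number 28.3 percentage points higher from compound 3 to compound 4 (beyond the scatter), so on this core the change has a real effect, even though it made no real difference on the core of compound 1. Read side by side, the two pairs show that this change does not carry over from one core to the other in this series, so the result on one core was a poor guide to the result on the other: the same change on two cores in this assay, a number 0.5 percentage points lower (within the scatter) from compound 1 to compound 2 and a number 28.3 percentage points higher (beyond the scatter) from compound 3 to compound 4, 28.8 percentage points apart, beyond the scatter of two such steps. Among the compounds shown here, these pairs do not show why the two cores respond differently, and with only two cores they give no general rule for what the same change would do on a third core, nor do they show that pyrrolidin-1-yl is better in general.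

What the compounds shown leave open is whether the rise seen with compound 4 depends on the size of the ring on the thiocarbonyl carbon, which a smaller azetidin-1-yl or a larger azepan-1-yl would help to test. On these data alone, it also remains open whether a ring with a second hetero atom, such as morpholin-4-yl, or an open-chain dimethylamino group would behave like pyrrolidin-1-yl on the core of compound 3.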